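Swapping the dichlorophenyl for a fluorophenyl on the sulfur

A few compounds are considered here, and "the series" means these few. Any claim that something is new, unique, unknown or untested is made for them only; others in the source may bear on it.

Among the compounds with values here, compound 2 `Nc1cc(N)c2nc(-c3ccccc3)c(Sc3ccc(Cl)c(Cl)c3)nc2c1` is the only compound with a definite number in a functional assay on DU-145 cells (Homo sapiens) for inhibition, read by sulforhodamine B assay, with a stated time of 48 h; on this read-out higher numbers stand for lower toxicity in this test and lower numbers for higher toxicity in this test; in this test compound 2 gives 9770 nM. Compound 1 `Nc1cc(N)c2nc(-c3ccccc3)c(Oc3ccc(Cl)c(Cl)c3)nc2c1` carries only a limit in this assay, and compound 1 is reported as < 100000 nM, which is a limit and not a number. Within the data shown here, the single measured step, a step that the limit leaves unreadable from compound 1 to compound 2, cannot be sized, as the limit of < 100000 nM in this assay, at which 1 of the 2 values shown sits, shows. Compound 3 `Nc1cc(N)c2nc(-c3ccccc3)c(Sc3ccc(F)cc3)nc2c1` differs from compound 2 by 4-fluorophenyl in place of 3,4-dichlorophenyl on a sulfur. No measured step touches this ring: the only comparison available, compound 1 against compound 2, concerns the atom linking the two rings rather than the ring itself, so the shown numbers give no direction for this change. The expectation for compound 3 is therefore a step of a 1.5-fold higher number from compound 2 to compound 3 (0.19 log units; within the scatter) that may well stay within the usual scatter, with a wide range allowed. Compound 3 is estimated at 15000 nM, between 4000 nM and 60000 nM.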

Compound 3, concentration lethal to 50% of the cells: < 100000 nM
Compound 3: no number, only a limit (the forecaster's own chance of this, stated with the estimate: 25%); the middle value lies beyond the limit too.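

No step can be read between compound 3 and compound 2 or compound 1, because each comparison runs into a limit and not a number: the limit of < 100000 nM in this assay, at which 2 of the 3 values shown sit. Still open, going by these compounds, is how 4-fluorophenyl on the sulfur compares with 3,4-dichlorophenyl in this assay.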